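This account rests on a few compounds, and the source may have more. Where it says the series, first, only, none or still open, it means among the compounds named here.

Compound 1 `O=C(CN1CCCCC1)Nc1ccc(-c2nc3cc(C(F)(F)F)ccc3[nH]2)cc1` in an ADME assay on MDBK cells (Bos taurus) for cytotoxicity, read by MTT assay, with a stated time of 96 h; a higher number here means that more compound is tolerated, a lower number that less compound is tolerated: 6000 nM
Compound 2 `CCN(CC)CC(=O)Nc1ccc(-c2nc3cc(C(F)(F)F)ccc3n2C)cc1` in this assay: 57000 nM

Of these two, compound 2 gives the higher number, meaning more of it is tolerated, and its gap to compound 1 lies beyond the usual scatter. Compound 3 `CN1CCN(CC(=O)Nc2ccc(-c3nc4cc(C(F)(F)F)ccc4n3C)cc2)CC1` differs from compound 2 in one place: 4-methylpiperazin-1-yl in place of diethylamino on a saturated chain carbon bound to a carbonyl carbon. Within the data shown here, no measured pair shows this particular change, and the rest of the structure is unchanged. The step from compound 2 to compound 3 in this assay is expected to be a 1.4-fold lower number from compound 2 to compound 3 (0.15 log units; within the scatter), none beyond the scatter. Compound 3 is therefore estimated at 40000 nM, within a range from 12000 nM to 120000 nM.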

Compound 3, half-maximal cytotoxic concentration: 44000 nM
Beside the measured number, compound 3's estimate is 1.1-fold (0.04 log units) below it, within the range that was stated.
By their numbers in this assay, from the lowest: compound 1; then compounds 3 and 2 (each within the scatter of the next).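

Placing 4-methylpiperazin-1-yl in place of diethylamino on the saturated chain carbon bound to a carbonyl carbon gives a 1.3-fold lower number from compound 2 to compound 3 (0.11 log units; within the scatter) in this assay, a step within the scatter. At this place, then, the open diethylamino group and the six-membered ring with its second nitrogen cannot be told apart in this read-out. No measurement here bears on the reason for this result.

On these data alone, whether a morpholine ring or a primary amine at the same place would also match compound 2 remains open.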